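Aryl variation on the ring amine: compound 3 to compound 4

A few compounds are considered here, and "the series" means these few. Any claim that something is new, unique, unknown or untested is made for them only; others in the source may bear on it.

The series shares the core of compound 1 `Cc1nc(-c2ccccc2)c(C(=O)N2CCN(c3cccc(C)c3C)CC2)o1`, which in a functional assay on HL-60 cells (Homo sapiens) for inhibition, read by MTT assay, with a stated time of 72 h (on this read-out higher numbers stand for weaker inhibition and lower numbers for stronger inhibition), gives 35 nM. Compound 2 `CC(=O)c1ccc(N2CCN(C(=O)c3oc(C)nc3-c3ccccc3)CC2)cc1` is reported in this assay as "not active" (no number reported), with no single number. Compound 3 `C=C(C)c1ccc(N2CCN(C(=O)c3oc(C)nc3-c3ccccc3)CC2)cc1` likewise stands in this assay at "not active" (no number reported), so no number fixes its place; it is one of two entries in the set without one, the other being compound 2. The change to compound 4 `Cc1cc(C)cc(N2CCN(C(=O)c3oc(C)nc3-c3ccccc3)CC2)c1` is 3,5-dimethylphenyl in place of 4-(1-methylethenyl)phenyl on an amine nitrogen in a ring. Going by the values given here, no measured pair carries this change, so its size is not known from the data. In the group on the amine nitrogen in the ring, compound 4 resembles compound 1 more than it resembles compound 3, and compound 1 is the one entry that gives a number in this assay, namely 35 nM, whereas compound 2 and compound 3 give none. The expectation is therefore a move from no reported activity to a measurable number, well beyond the scatter, with the caution that the 3,5-dimethylphenyl is not the group of compound 1 and may fall short of it. Compound 4 is estimated at 150 nM, within a range of 30 nM to 3000 nM.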

Compound 4, half-maximal inhibitory concentration: 34.5 nM
Beside the measured number, compound 4's estimate is 4.3-fold (0.64 log units) above it, and the stated range covers the measured number.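

In this assay, compound 4 shows that a measurable number at this position does not depend on the 2,3-dimethylphenyl of compound 1: the step to 3,5-dimethylphenyl is a 1.0-fold lower number from compound 1 to compound 4 (0.01 log units; within the scatter), so these two methyl arrangements are not separated. Among the four compounds, both dimethylphenyl compounds give numbers while compound 2 and compound 3 are reported as not active, but the size of the change from 4-(1-methylethenyl)phenyl to 3,5-dimethylphenyl cannot be read, as compound 3 has no number. No evidence here accounts for this difference between the compounds.

As far as these compounds go, it remains open whether an unsubstituted phenyl or a single methyl group on the phenyl would keep a number at this position. From the compounds shown here alone, a methoxy or an amine on the phenyl is equally open.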